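The source may hold more compounds than are shown below. What is called first, only, known or untested is meant among the compounds shown, and "the series" means these compounds.

Working notes on the series.

Compound 1 `COc1ccccc1Oc1ccc2c(NCCCNCc3ccco3)ccnc2c1` is the reference point. In a physicochemical assay for acid dissociation, compound 1 gives 9.28. For the measured compounds named here, compound 2 `COc1cccc(Oc2ccc3c(NCCCNCc4cc(F)ccc4OC)ccnc3c2)c1` is the only other measured member; in this assay compound 2 gives 9.28, level with compound 1 at the digits recorded, so the two differ by nothing beyond the scatter. Going by the values given here, no single-point step between measured compounds is available.

Compound 3 `Fc1ccc(Cc2ccc3c(NCCCNCc4ccco4)ccnc3c2)c(Cl)c1` is not yet measured. Its change from compound 1 is 2-chloro-4-fluorobenzyl in place of 2-methoxyphenoxy on an aromatic carbon. The group that leaves and the group that enters both sit on the shared core, away from the chain carrying the two nitrogens.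

Compound 3 is expected to land close to compound 1 on the numbers seen, with the step from compound 1 to compound 3 estimated at a number 0.02 log units higher from compound 1 to compound 3 (within the scatter), that is, no shift beyond the scatter in either direction. The estimate for compound 3 in this assay is 9.3, with a range of 8.9 to 9.7.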

Compound 3, acid dissociation constant: 9.47
Beside the measured number, compound 3's estimate is 0.17 log units below it; measured number inside the range.
By their numbers in this assay, from the lowest: compounds 1, 2 and 3 (each within the scatter of the next).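

For the compounds shown here, the step of a number 0.19 log units higher from compound 1 to compound 3 (within the scatter) in this assay is the first single-place reading, and it comes from placing 2-chloro-4-fluorobenzyl in place of 2-methoxyphenoxy on an aromatic carbon of the shared core. At this position, therefore, a group with no hydrogen-bond acceptors can replace one with hydrogen-bond acceptors, at the same heavy-atom count, without a shift beyond the scatter. Nothing measured on these compounds offers an account of this result.

From the compounds shown here alone, whether an amine or a carboxylic acid on the same aromatic carbon would also stay within the scatter remains open. The compounds shown also leave open how the read-out responds to a change in the chain carrying the two nitrogens, such as a longer chain.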